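The source may report more compounds than this note shows. Statements on the series, on what has been measured and on what is new or still open speak of the compounds shown alone.

Measured compounds in the series:

compound 1 `Nc1nn(C(=O)Nc2ccc(Cc3ccccc3)cc2)c2ccccc12` — in a functional assay on OVCAR-3 cells (Homo sapiens) for antiproliferative activity, read by sulforhodamine B assay, with a stated time of 48 h (a higher number here means a weaker inhibitor of growth, a lower number a stronger inhibitor of growth), compound 1 gives 6230 nM
compound 2 `Nc1nn(C(=O)Nc2ccc(Cc3ccccc3)cc2)c2ccc(Cl)cc12` — in this assay compound 2 gives 6660 nM

Compound 2 sits alongside compound 1 on the two numbers available: the step of a 1.1-fold higher number from compound 1 to compound 2 (0.03 log units; within the scatter) shows that putting chloro in place of hydrogen on an aromatic carbon of the shared core left the result unchanged within the scatter, so neither compound can be set above the other.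

Compound 3 `Nc1ccc2c(c1)c(N)nn2C(=O)Nc1ccc(Cc2ccccc2)cc1` is the next compound to be measured. Relative to compound 2 the change is amino in place of chloro on an aromatic carbon.

Among the measured compounds shown here, the only measured step that bears on this position is a 1.1-fold higher number from compound 1 to compound 2 (0.03 log units; within the scatter), which touched the same aromatic carbon and stayed within the scatter. For the measured compounds named here, no measured pair shows amino entering anywhere, so there is no direct precedent for this group. Given that the one change made at this site produced no shift, the expectation for this assay is a step of about a 1.0-fold lower number from compound 2 to compound 3 (0.01 log units; within the scatter), that is, none beyond the scatter in either direction.

Compound 3 is therefore estimated at 6500 nM, with a range from 3000 nM to 14000 nM.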

Compound 3, concentration for 50% growth inhibition: 12100 nM
The estimate for compound 3 lay 1.9-fold (0.27 log units) below the measured number, within the range that was stated.
By their numbers in this assay, from the lowest: compounds 1, 2 and 3 (each within the scatter of the next).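

Amino in place of chloro on this aromatic carbon, the place para to a fused ring and meta to a fused ring, gives in this assay a step that stays within the scatter (a 1.8-fold higher number from compound 2 to compound 3 (0.26 log units; within the scatter)), and amino in place of hydrogen does the same (a 1.9-fold higher number from compound 1 to compound 3 (0.29 log units; within the scatter)). The earlier compounds shown here showed only chloro and hydrogen at this carbon; the site now holds three groups, including amino, which brings a hydrogen-bond donor and a hydrogen-bond acceptor where chloro brings neither, and no step among them lies beyond the scatter, so compound 1, compound 2 and compound 3 cannot be ranked against one another. Nothing measured alongside these numbers accounts for the result or bears on it.

As far as these compounds go, whether any other group on this aromatic carbon, such as methoxy, a nitrile or a carboxylic acid, would give a step beyond the scatter remains open. Also open, from the compounds shown here alone, is whether a change elsewhere on the shared core, such as fluoro on another aromatic carbon, would move the number further than any change at this site has done.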